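Same Ring Swap, Second Core: What Compound 4 Should Show

The compounds below may be only part of what the source reports. "The series", "measured", "known", "first", "only" and "open" are said of these compounds alone.

Compound 1 `Cc1ccc(NC(=S)NC(=O)c2ccc(OCc3ccccc3F)cc2)cc1-c1nc2ccccc2[nH]1` and compound 3 `Cc1ccc(NC(=O)NC(=O)c2ccc(OCc3ccccc3F)cc2)cc1-c1nc2ccccc2[nH]1` are built on closely related cores; the difference between the two cores is not broken down here. In a functional assay on SW-620 cells (Homo sapiens) for inhibition, read by MTT assay, with a stated time of 48 h (a higher number here means a weaker inhibitor, a lower number a stronger inhibitor), compound 1 gives 6440 nM. In this assay compound 3 gives 4110 nM, a value within the usual scatter of compound 1, so the two cannot be told apart on this measure.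

Compound 2 `Cc1ccc(NC(=S)NC(=O)c2ccc(OCc3cccc(Cl)c3Cl)cc2)cc1-c1nc2ccccc2[nH]1` is made from compound 1 by one change: 2,3-dichlorophenyl in place of 2-fluorophenyl on a saturated chain carbon bound to an oxygen on an aromatic ring. In this assay compound 2 reaches only a limit, > 100000 nM, and no number is known. The step of an at least 15-fold higher number from compound 1 to compound 2 (1.19 log units; beyond the scatter) is therefore a large weakening, with the end of it hidden by the limit of > 100000 nM in this assay, at which 1 of the 3 values shown sits.

Compound 4 `Cc1ccc(NC(=O)NC(=O)c2ccc(OCc3cccc(Cl)c3Cl)cc2)cc1-c1nc2ccccc2[nH]1` has not yet been measured. It stands to compound 3 exactly as compound 2 stands to compound 1, through the same change: 2,3-dichlorophenyl in place of 2-fluorophenyl on a saturated chain carbon bound to an oxygen on an aromatic ring. Since the surroundings of the change are the same in both pairs, the earlier step is the best guide. Compound 4 is expected to weaken by roughly a 19-fold higher number from compound 3 to compound 4 (1.29 log units; beyond the scatter) in this assay, because the same change from compound 1 to compound 2 gave an at least 15-fold higher number from compound 1 to compound 2 (1.19 log units; beyond the scatter). Compound 4 is thus estimated at about 80000 nM in this assay, with a likely range from 20000 nM to 300000 nM, and a real chance that only a limit is reported.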

Compound 4, half-maximal inhibitory concentration: 42100 nM
The estimate for compound 4 lay 1.9-fold (0.28 log units) above the measured number, within the range that was stated.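

In this assay, putting 2,3-dichlorophenyl in place of 2-fluorophenyl also weakens the compound on the second core, with a 10-fold higher number from compound 3 to compound 4 (1.01 log units; beyond the scatter). Set beside the first core, the change points the same way and is large on both: the same change on two cores in this assay, an at least 15-fold higher number (1.19 log units; beyond the scatter) from compound 1 to compound 2 and a 10-fold higher number (1.01 log units; beyond the scatter) from compound 3 to compound 4; the limit leaves it open whether they differ

Compound 2 reaches only a limit, > 100000 nM, so these pairs show that the direction and broad scale of the effect carry over, but they do not show that its exact size is the same on both cores, and two closely related cores cannot show how the change would behave on a more distant one.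

The compounds shown have only 2-fluorophenyl or 2,3-dichlorophenyl at this place, so it remains open whether a phenyl ring carrying a single chlorine, a methoxy group or an amine would keep the activity or lose it. On these data alone, it also remains open whether the same weakening would appear in a cell line other than the one tested here, since all of these comparisons come from a single assay.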